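The compounds below may be only part of what the source reports. "The series", "measured", "known", "first", "only" and "open" are said of these compounds alone.

Three related compounds have been tested in a functional assay on the whole organism (strain albino) for inhibition, with Rattus norvegicus as the target, read by paw edema, with a stated time of 2 h, at a dose of 0.28 mmol/kg by the oral route; on this read-out higher numbers stand for more inhibition at the one dose given (going by the name of the read-out) and lower numbers for less inhibition. Compound 1 `CCn1c(SCC(=O)c2ccccc2)nnc1-c1ccc(OC)cc1` gives 60%, compound 2 `CCn1c(SCC(=O)c2ccccc2)nnc1-c1ccccc1` gives 55%, and compound 3 `CCn1c(SC/C(=N/O)c2ccccc2)nnc1-c1cc(OC)c(OC)c(OC)c1` gives 67%. Compound 2 differs from compound 1 by hydrogen in place of methoxy on an aromatic carbon, and this change made a step of a number 5 percentage points lower from compound 1 to compound 2 (within the scatter). Compound 4 `CCn1c(SC/C(=N/O)c2ccccc2)nnc1-c1ccc(OC)c(OC)c1` has not yet been measured; it differs from compound 3 by hydrogen in place of methoxy on an aromatic carbon. That is the same kind of change as before, though the surroundings differ: in the earlier pair the position is para to a large group, whereas here it is ortho to a methoxy group, meta to a large group and meta to a methoxy group. How the core of compound 3 differs from that of compound 1 is not broken down here. Resting on the earlier step of a number 5 percentage points lower from compound 1 to compound 2 (within the scatter), the step from compound 3 to compound 4 is expected to be a number 5 percentage points lower from compound 3 to compound 4 (within the scatter). Compound 4 is therefore estimated at 62%, probably between 50% and 74%.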

Compound 4, a percentage reported as inhibition, in the whole organism at one dose (the size of the read-out at that dose, not a potency): 67%
Compound 4: middle estimate off by 5 percentage points, on the low side, within the range that was stated.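

In this assay, putting hydrogen in place of a methoxy group gave no change at the digits printed from compound 3 to compound 4 (within the scatter). Set beside the earlier step, the change carries from one core to the other without a detectable difference: the same change on two cores in this assay, a number 5 percentage points lower (within the scatter) from compound 1 to compound 2 and no change at the digits printed (within the scatter) from compound 3 to compound 4, 5 percentage points apart, within the scatter of two such steps. Both steps lie within the scatter, so this does not show that the methoxy group matters or does not matter, and two pairs at one dose, with the change at different places on the ring, cannot speak for other places or other cores.

Going by these compounds, whether an amine or a carboxylic acid in place of the methoxy group would leave the read-out as undisturbed stays open. So does the effect of a longer chain in place of the ethyl group.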